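A few compounds are considered here, and "the series" means these few. Any claim that something is new, unique, unknown or untested is made for them only; others in the source may bear on it.

Working notes on the series. In a functional assay on DU-145 cells (Homo sapiens) for cytotoxicity, read by sulforhodamine B assay, with a stated time of 48 h (on this read-out lower numbers stand for stronger inhibition and higher numbers for weaker inhibition), compound 1 `COc1ccc(C2=NO[C@]3(C2)C(=O)O[C@@H]2[C@H]3CC[C@H](C)[C@]3(O)C=CC(=O)[C@@]23C)cc1OC` gives 84000 nM and compound 2 `COc1cc(C2=NO[C@]3(C2)C(=O)O[C@@H]2[C@H]3CC[C@H](C)[C@]3(O)C=CC(=O)[C@@]23C)ccc1O` gives 71000 nM, while compound 3 `C[C@H]1CC[C@@H]2[C@@H](OC(=O)[C@]23CC(c2ccccc2F)=NO3)[C@]2(C)C(=O)C=C[C@@]12O` gives 24000 nM, the lowest number of the three, with its steps to both others beyond the scatter.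

The next structure is compound 4 `C[C@H]1CC[C@@H]2[C@@H](OC(=O)[C@]23CC(c2ccccc2Cl)=NO3)[C@]2(C)C(=O)C=C[C@@]12O`, which differs from compound 3 at one place: chloro in place of fluoro on an aromatic carbon. In words, this is chloro in place of fluoro on an aromatic carbon.

Going by the values given here, no measured step exchanges one halogen for another, so the evidence is indirect. Replacing the whole substituted phenyl group gave modest shifts, a 3.5-fold lower number from compound 1 to compound 3 (0.54 log units; beyond the scatter) and a 3.0-fold lower number from compound 2 to compound 3 (0.47 log units; beyond the scatter). Hydrogen in place of methyl on an aromatic oxygen gave a 1.2-fold lower number from compound 1 to compound 2 (0.07 log units; within the scatter), within the scatter. The swap at hand is far smaller than the two phenyl replacements, so no shift beyond the scatter is expected in this assay, and no direction can be argued from these data. The expected step is a 1.1-fold lower number from compound 3 to compound 4 (0.04 log units; within the scatter), which is read as no real change.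

Compound 4 is estimated at 22000 nM, with an expected range from 9000 nM to 52000 nM.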

Compound 4, half-maximal inhibitory concentration: 19000 nM
For compound 4 the middle estimate is 1.2-fold (0.06 log units) above the measured one; the range from low to high includes it.
By their numbers in this assay, from the lowest: compounds 4 and 3 (each within the scatter of the next); then compounds 2 and 1 (each within the scatter of the next).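

In this assay, going by these compounds alone, chloro in place of fluoro on an aromatic carbon, ortho to a large group, is the first halogen exchange, and it gives a 1.3-fold lower number from compound 3 to compound 4 (0.10 log units; within the scatter) with the two compounds not separated by this read-out. The step from the 4-hydroxy-3-methoxyphenyl compound to the 2-chlorophenyl compound reads a 3.7-fold lower number from compound 2 to compound 4 (0.57 log units; beyond the scatter) and the step from the 3,4-dimethoxyphenyl compound reads a 4.4-fold lower number from compound 1 to compound 4 (0.65 log units; beyond the scatter) so the modest shift first seen with 2-fluorophenyl holds with 2-chlorophenyl too, and among these four compounds neither oxygen-bearing phenyl compound goes against it. No accompanying measurement speaks to why these numbers fall as they do.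

The compounds shown carry a halogen only ortho to a large group, so they do not separate the effect of the halogen from that of its place on the ring or from the loss of the methoxy group. Going by these compounds, how bromo, an amine or a carboxylic acid on the same aromatic carbon would read in this assay also remains open.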